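Adenosine-like Benzylamines: Weak Growth Inhibition So Far

This account rests on a few compounds, and the source may have more. Where it says the series, first, only, none or still open, it means among the compounds named here.

The compounds share one core carrying a benzyl group on an amine. Compound 1 `OC[C@H]1O[C@@H](n2cnc3c(NCc4cccc(Br)c4)ncnc32)[C@H](O)[C@@H]1O` bears a 3-bromophenyl there, compound 2 `COc1ccccc1CNc1ncnc2c1ncn2[C@@H]1O[C@H](CO)[C@@H](O)[C@H]1O` a 2-methoxyphenyl, and compound 3 `COc1ccc(CNc2ncnc3c2ncn3[C@@H]2O[C@H](CO)[C@@H](O)[C@H]2O)c(OC)c1` a 2,4-dimethoxyphenyl. In a functional assay on G-361 cells (Homo sapiens) for antiproliferative activity, with a stated time of 72 h (on this read-out higher numbers stand for weaker inhibition and lower numbers for stronger inhibition), compound 1 gives only a limit, > 166000 nM. Compound 2 likewise gives only a limit, > 166000 nM, in this assay. The step that the two limits leave unreadable from compound 1 to compound 2 therefore cannot be read, as both ends sit at the limit of > 166000 nM in this assay, at which 2 of the 3 values shown sit. For compound 3, this assay gives "not determined" (no result reported), so it stands without any number of its own. The values of compound 1 and compound 2 around it are both limits.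

Compound 4 `Cc1ccc(O)c(CNc2ncnc3c2ncn3[C@@H]2O[C@H](CO)[C@@H](O)[C@H]2O)c1` is made from compound 3 by the change (2-hydroxy-5-methylphenyl in place of 2,4-dimethoxyphenyl on a saturated chain carbon bound to a nitrogen on an aromatic ring). Among the compounds with values here, no measured step bears on this change in a readable way, since every measured value is a limit, and no direction or size of step can be expected from the numbers. Given that compound 1 sits at the limit of > 166000 nM in this assay, at which 2 of the 3 values shown sit, and compound 2 at the same limit, compound 4 is expected to fall near 150000 nM, within a range from 30000 nM to 600000 nM, and most likely to be reported only as a limit.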

Compound 4, half-maximal inhibitory concentration: > 166000 nM
Compound 4: only a limit was reported (the forecaster's own chance of this, stated with the estimate: 70%); at least 1.1-fold (0.04 log units) between middle value and limit.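

Compound 4 gives only a limit, > 166000 nM, in this assay. The steps to compound 4 from compound 1 and compound 2 therefore cannot be read: the limit of > 166000 nM in this assay, at which 3 of the 4 values shown sit. The compounds shown leave open whether any benzyl group on the shared core can give a measurable value in this assay.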